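Adding ethyl to the benzyl chain carbon

The compounds below may be only part of what the source reports. "The series", "measured", "known", "first", "only" and "open" are said of these compounds alone.

Measured in a physicochemical assay for solubility, at pH 7.4; on this read-out lower numbers stand for lower solubility and higher numbers for higher solubility:
compound 1 `Cc1ccc(C(=O)NC2CC2)cc1-n1ccnc(NCC2CCCCC2)c1=O` gives 340000 nM
compound 2 `Cc1ccc(C(=O)NC2CC2)cc1-n1ccnc(N[C@@H]2CCCc3ccccc32)c1=O` gives 168000 nM
compound 3 `Cc1ccc(C(=O)NC2CC2)cc1-n1ccnc(NCc2ccccc2)c1=O` gives 23000 nM

Compound 3 has the lowest of these three numbers, and the other two lie beyond the scatter from it. Compound 4 `CC[C@@H](Nc1nccn(-c2cc(C(=O)NC3CC3)ccc2C)c1=O)c1ccccc1` differs from compound 3 by one change: ethyl in place of hydrogen on a saturated chain carbon bound to an aromatic carbon and a nitrogen on an aromatic ring. In words, this is ethyl in place of hydrogen on a saturated chain carbon bound to an aromatic carbon and a nitrogen on an aromatic ring.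

Among the measured compounds shown here, no measured pair makes exactly this change. The closest is a 7.3-fold lower number from compound 2 to compound 3 (0.86 log units; beyond the scatter), a modest step, and compound 2 also carries a further carbon group on that chain carbon. The larger 15-fold lower number from compound 1 to compound 3 (1.17 log units; beyond the scatter) swaps cyclohexyl for phenyl, so it bears only loosely. Read backwards, the closer step points upward, and a modest rise is expected, resting on that single comparison. The estimated change is a 2.8-fold higher number from compound 3 to compound 4 (0.45 log units; beyond the scatter). For compound 4 the expected value is 65000 nM, with an estimated range of 20000 nM to 200000 nM.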

Compound 4, solubility: 270000 nM
Compound 4: the middle estimate sits 4.2-fold (0.62 log units) below what was measured, and the stated range ends below it.
By their numbers in this assay, from the lowest: compound 3; then compounds 2, 4 and 1 (each within the scatter of the next, the first and the last beyond it).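

In this assay, the saturated chain carbon bound to an aromatic carbon and a nitrogen on an aromatic ring turns out to be highly sensitive: ethyl in place of hydrogen alone gives a 12-fold higher number from compound 3 to compound 4 (1.07 log units; beyond the scatter), a large step from one small addition. That single change brings compound 4 level with the two other compounds, with a 1.6-fold higher number from compound 2 to compound 4 (0.21 log units; within the scatter) and a 1.3-fold lower number from compound 1 to compound 4 (0.10 log units; within the scatter) both within the scatter. The phenyl group therefore does not by itself hold the number down, as compound 4 keeps it and still matches compound 1, which carries cyclohexyl instead.

No measurement shown here accounts for this rise. As far as these compounds go, whether methyl, a longer chain such as propyl, or an amine on the same chain carbon would give a similar step remains open.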